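The source may report more compounds than this note shows. Statements on the series, on what has been measured and on what is new or still open speak of the compounds shown alone.

Measured compounds:
compound 1, `CCn1c(=O)/c(=C2\Sc3ccccc3N2C)s/c1=C\c1ccncc1Nc1ccccc1F`, in a functional assay on MCF7 cells (Homo sapiens) for inhibition (on this read-out lower numbers stand for stronger inhibition and higher numbers for weaker inhibition), compound 1 gives 330 nM
compound 2, `CCn1c(=O)/c(=C2\Sc3cc(F)ccc3N2C)s/c1=C\c1ccncc1Nc1ccccc1F`, in this assay compound 2 gives 230 nM

Compound 1 stands highest of the two numbers, its nearest neighbour being compound 2; the step of a 1.4-fold lower number from compound 1 to compound 2 (0.16 log units; within the scatter) is within the scatter. Compound 3, `CCn1c(=O)/c(=C2\Sc3ccccc3N2C)s/c1=C\c1ccncc1Nc1cc(C)ccc1C`, differs from compound 1 by 2,5-dimethylphenyl in place of 2-fluorophenyl on a nitrogen on an aromatic ring. Going by the values given here, no measured pair covers a change at this nitrogen; the one step known concerns a fluoro on a different ring and does not bear on it. The change is therefore expected to give no step beyond the scatter in this assay, that is a 1.2-fold higher number from compound 1 to compound 3 (0.08 log units; within the scatter). For compound 3 the estimate is 400 nM, with a range from 130 nM to 1200 nM.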

Compound 3, half-maximal inhibitory concentration: 1700 nM
Compound 3: the middle estimate sits 4.3-fold (0.63 log units) below what was measured, outside the stated range (above it).
By their numbers in this assay, from the lowest: compounds 2 and 1 (each within the scatter of the next); then compound 3.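

In this assay the aryl group on this nitrogen turns out to matter: 2,5-dimethylphenyl in place of 2-fluorophenyl gives a 5.2-fold higher number from compound 1 to compound 3 (0.71 log units; beyond the scatter) and so weakens inhibition, the only step shown beyond the scatter. No available measurement bears on the reason for this loss.

The compounds shown leave open whether the loss of fluoro or the gain of the two methyl groups drives the step. Also open, going by these compounds, is how plain phenyl or a phenyl ring carrying a carboxylic acid would read at this nitrogen.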